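Methyl for Fluoro at the Edge of Detection

The source may report more compounds than this note shows. Statements on the series, on what has been measured and on what is new or still open speak of the compounds shown alone.

Compound 1 `Cc1cc(OCc2sc(-c3ccc(C(F)(F)F)cc3)nc2C)ccc1OCC(=O)O` in an assay on CHO cells for agonist activity at Free fatty acid receptor 1 (Homo sapiens), read by FLIPR (on this read-out lower numbers stand for an effect already at smaller amounts and higher numbers for an effect only at larger amounts of compound), gives > 10000 nM, a limit of the assay.
Compound 2 `Cc1nc(-c2ccc(C(F)(F)F)cc2)sc1COc1ccc(OCC(=O)O)c(F)c1` in this assay gives 149 nM.
Compound 3 `O=C(O)COc1ccc(OCc2nnc(-c3ccccc3)s2)cc1F` in this assay gives > 10000 nM, a limit of the assay.

Among the measured compounds shown here, the single change methyl in place of fluoro on an aromatic carbon brought an at least 67-fold higher number from compound 2 to compound 1 (1.82 log units; beyond the scatter). Compound 4 `Cc1cc(OCc2nnc(-c3ccccc3)s2)ccc1OCC(=O)O` is the same change made on the core of compound 3, namely (methyl in place of fluoro on an aromatic carbon); how that core differs from the core of compound 2 is not broken down here. Compound 3 already sits at a limit in this assay, and the earlier step points toward weaker activity still. For compound 4 the expected step is a step that the limit leaves unreadable from compound 3 to compound 4, which rests on an at least 67-fold higher number from compound 2 to compound 1 (1.82 log units; beyond the scatter) together with the limit of > 10000 nM in this assay, at which 2 of the 3 values shown sit. Compound 4 is therefore expected to give about 30000 nM in this assay, most likely reported as a limit rather than a number.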

Compound 4, half-maximal effective concentration: > 10000 nM
Compound 4: no number, only a limit; the forecaster's own chance of this, stated with the estimate: 90%; the middle value does not contradict the limit.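

Among the compounds shown here, compound 3 and compound 4 both stand at a limit in this assay, so no step between them can be read: the limit of > 10000 nM in this assay, at which 3 of the 4 values shown sit. The compounds shown leave open whether methyl in place of fluoro changes anything on the core of compound 3.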